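A few compounds are considered here, and "the series" means these few. Any claim that something is new, unique, unknown or untested is made for them only; others in the source may bear on it.

Measured so far:
- compound 1, `N#Cc1c(-c2ccco2)[n+]([O-])c2ccc(C(F)(F)F)cc2[n+]1[O-]`: 1.5
- compound 2, `COc1ccc(-c2c(C#N)[n+]([O-])c3cc(C(F)(F)F)ccc3[n+]2[O-])cc1`: 2.45
- compound 3, `COc1ccc(-c2c(C#N)[n+]([O-])c3cc(F)c(F)cc3[n+]2[O-])cc1`: 2.09

All three numbers come from a physicochemical assay for lipophilicity, measured as octanol-water partition; a lower number here means a more polar compound, a higher number a more lipophilic compound. In this assay compound 2 gives 2.45 and compound 1 gives 1.5. These two differ in one place only: furan-2-yl in place of 4-methoxyphenyl on an aromatic carbon. That single change produced a number 0.95 log units lower from compound 2 to compound 1 (beyond the scatter).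

In this assay compound 3 gives 2.09. Compound 3 and compound 2 differ in their cores, and that difference is not broken down here; what the values show is that compound 3 sits lower than compound 2, beyond the scatter, and higher than compound 1, also beyond the scatter.

Not yet measured is compound 4, `N#Cc1c(-c2ccco2)[n+]([O-])c2cc(F)c(F)cc2[n+]1[O-]`. It differs from compound 3 as follows: furan-2-yl in place of 4-methoxyphenyl on an aromatic carbon. The surroundings of the place are described in the same words as for the pair compound 2 to compound 1, so this is the same change made on the core of compound 3 instead of the core of compound 2. The expectation for compound 4 rests on that one precedent alone, as no second instance of the change is available. The step expected from the change is a number 0.94 log units lower from compound 3 to compound 4 (beyond the scatter), to be read beside a number 0.95 log units lower from compound 2 to compound 1 (beyond the scatter). For compound 4 in this assay the estimated value is 1.15, expected to fall between 0.8 and 1.5.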

Compound 4, partition coefficient: 1.38
For compound 4 the middle estimate is 0.23 log units below the measured one, within the range that was stated.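

In this assay the replacement of 4-methoxyphenyl by furan-2-yl on an aromatic carbon gives a number 0.71 log units lower from compound 3 to compound 4 (beyond the scatter) and, on the other core, a number 0.95 log units lower from compound 2 to compound 1 (beyond the scatter) as the matching step, so the number falls on both cores shown and the direction of the change carries from one core to the other. With only these two pairs in hand, this does not show that the step has a fixed size, nor that the same direction would hold on a core beyond those of compound 2 and compound 3. Nothing measured here bears on what lies behind either step.

The compounds shown carry only 4-methoxyphenyl or furan-2-yl on this aromatic carbon, so it remains open how the number would move with a saturated amine such as piperidine, a carboxylic acid or a longer alkyl chain at the same place. The cores shown carry only trifluoromethyl or two fluorines on the fused ring, and the nitrile is constant throughout, so the same exchange on a core bearing chlorine, or with a primary amide in place of the nitrile, also remains open.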